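The source may report more compounds than this note shows. Statements on the series, on what has been measured and on what is new or still open speak of the compounds shown alone.

Measured so far:
- compound 1 `CCCCCCNC(=O)NS(=O)(=O)N1CCC(CNC(=O)c2cc(Cl)ccc2OC)CC1`, giving 17%
- compound 2 `CC(=O)NCCC1CCN(S(=O)(=O)NC(=O)NC[C@@H]2C[C@@H]3C=C[C@@H]2C3)CC1`, giving 18%

Both were tested in a functional assay on the whole organism (blood) with Rattus norvegicus as the target, with stated times of 24 h and 1 h, at a dose of 5 mg/kg by the intraperitoneal route; on this read-out lower numbers stand for a weaker effect and higher numbers for a stronger effect at the one dose given. On this read-out compound 2 has the higher of the two numbers, but compound 1 lies only a little beneath it, and the two values fall within the scatter of each other, so the data do not separate them. Going by the values given here, no step between compounds that differ in a single place has been worked out here, so the measured pair gives no direct guide to how a small change shifts the read-out.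

Compound 3 `O=C(NC[C@@H]1C[C@@H]2C=C[C@@H]1C2)NS(=O)(=O)N1CCC(CCNC(=O)C(F)(F)F)CC1` has not yet been tested. It differs from compound 2 in one place: trifluoromethyl in place of methyl on a carbonyl carbon. The amide of the side chain keeps its carbonyl and its nitrogen; only the group on the carbonyl carbon is exchanged.

Among the compounds with values here, with no measured step to lean on, the expectation for this exchange is a step from compound 2 to compound 3 of a number 2 percentage points higher from compound 2 to compound 3 (within the scatter), that is, none beyond the scatter in either direction. Compound 3 is therefore estimated at 20%, within a range from 5% to 40%.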

Compound 3, a percentage reported as activity, at one dose (the size of the read-out at that dose, not a potency): 22%
Compound 3: the middle estimate sits 2 percentage points below what was measured; measured number inside the range.
By their numbers in this assay, from the lowest: compounds 1, 2 and 3 (each within the scatter of the next).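

In this assay, going by these compounds alone, putting trifluoromethyl in place of methyl on a carbonyl carbon gives the first measured change at a single place in this set, a number 4 percentage points higher from compound 2 to compound 3 (within the scatter), a step that stays within the scatter. The exchange raises the group on the carbonyl carbon from one heavy atom to four, three of them fluorine, yet this read-out at the one dose does not separate the two compounds, so at this position the exchange has no effect that can be told from the scatter. No measurement is available that bears on this result, so nothing can be said about what lies behind it.

From the compounds shown here alone, a single step within the scatter does not show how much room this position has, and it remains open whether a phenyl ring, a tert-butyl group or a longer chain on the same carbonyl carbon would also leave the read-out within the scatter of compound 2. Going by these compounds, it also remains open whether a group carrying an amine or a carboxylic acid there would shift the read-out beyond the scatter.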